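Thiophene for Pyridine on the Shared Core

This account rests on a few compounds, and the source may have more. Where it says the series, first, only, none or still open, it means among the compounds named here.

Among the compounds with values here, compound 1 `c1cncc(-c2ccccc2OCC2=NCCN2)c1` is the only member of this small set with a measured number: in a functional assay for activation of Alpha-1D adrenergic receptor (Homo sapiens), read by calcium flux (on this read-out lower numbers stand for an effect already at smaller amounts and higher numbers for an effect only at larger amounts of compound), compound 1 gives 158 nM. Compound 2 `c1coc(-c2ccccc2OCC2=NCCN2)c1` reaches only a limit of the assay in this assay, where compound 2 gives < 100000 nM. Compound 3 `Cc1ccoc1-c1ccccc1OCC1=NCCN1` likewise stops at a limit in this assay, as compound 3 gives < 100000 nM. Compound 4 `Cc1ccc(-c2ccccc2OCC2=NCCN2)s1` has not yet been measured and differs from compound 1 in one place: 5-methylthiophen-2-yl in place of pyridin-3-yl on an aromatic carbon. The measured steps that bear on this change also replace the pyridin-3-yl with a five-membered ring, a step that the limit leaves unreadable from compound 1 to compound 2 and a step that the limit leaves unreadable from compound 1 to compound 3, but the limit of < 100000 nM in this assay, at which 2 of the 3 values shown sit, leaves their size unreadable, so they offer no number to lean on. The step between the two five-membered rings, a step that the two limits leave unreadable from compound 2 to compound 3, is unreadable for the same reason. Compound 4 is therefore expected to sit within a broad span around its parent, a 2.5-fold higher number from compound 1 to compound 4 (0.40 log units; beyond the scatter). The estimate for compound 4 in this assay is 400 nM, between 60 nM and 5000 nM.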

Compound 4, half-maximal effective concentration: < 100000 nM
Compound 4 ended at the assay's limit (the forecaster's own chance of this, stated with the estimate: 30%); the middle value does not contradict the limit.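

The steps from compound 1, compound 2 and compound 3 to compound 4 cannot be read, because their values do not give sizes: the limit of < 100000 nM in this assay, at which 3 of the 4 values shown sit.

Going by these compounds, how large the gap is between compound 1 and each of compound 2, compound 3 and compound 4 stays open.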